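Naphthalen-2-yl Replaces Dimethylphenyl on the Ring Amide Nitrogen

The source may report more compounds than this note shows. Statements on the series, on what has been measured and on what is new or still open speak of the compounds shown alone.

Compound 3 `Cc1ccc(N2C(=O)[C@H]3[C@H](ON4[C@@H]3C(=O)N(C)[C@@]43C[C@H](C)CC[C@H]3C(C)C)C2=O)c(C)c1` stands second highest of the three numbers in a functional assay, read by spectrophotometry, with a stated time of 2 h, tested at 3 mg/mL (on this read-out higher numbers stand for a stronger effect at the one concentration tested and lower numbers for a weaker effect), where compound 3 gives 71.3%. Compound 2 `CC(C)[C@@H]1CC[C@@H](C)C[C@@]12N(C)C(=O)[C@@H]1[C@H]3C(=O)N(c4ccc(Cl)cc4)C(=O)[C@H]3ON12` gives 73.3% in this assay, and compound 1 `CC(C)[C@@H]1CC[C@@H](C)C[C@@]12N(C)C(=O)[C@@H]1[C@H]3C(=O)N(C)C(=O)[C@H]3ON12` gives 67.5% in this assay. All three sit within the scatter of one another: a number 5.8 percentage points higher from compound 1 to compound 2 (within the scatter), a number 3.8 percentage points higher from compound 1 to compound 3 (within the scatter), and a number 2 percentage points lower from compound 2 to compound 3 (within the scatter). Compound 4 `CC(C)[C@@H]1CC[C@@H](C)C[C@@]12N(C)C(=O)[C@@H]1[C@H]3C(=O)N(c4ccc5ccccc5c4)C(=O)[C@H]3ON12` differs from compound 3 in one place: naphthalen-2-yl in place of 2,4-dimethylphenyl on an amide-type nitrogen in a ring. The measured steps that bear on this change are the three at the same amide-type nitrogen in a ring, where methyl, 4-chlorophenyl and 2,4-dimethylphenyl all gave numbers within the scatter of each other, and none of them moved the read-out beyond it. No step beyond the scatter is therefore expected in this assay when one carbon ring on that nitrogen gives way to another; compound 4 is expected to show a number 0.7 percentage points higher from compound 3 to compound 4 (within the scatter). Compound 4 is estimated at 72% in this assay, with a range from 60% to 82%.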

Compound 4, a percentage reported as activity, at one concentration (the size of the read-out at that concentration, not a potency): 57.4%
For compound 4 the middle estimate is 14.6 percentage points above the measured one; measured number below the stated range.
By their numbers in this assay, from the lowest: compound 4; then compounds 1, 3 and 2 (each within the scatter of the next).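

On the amide-type nitrogen in a ring, the read-out in this assay is not indifferent to the group carried: naphthalen-2-yl gives a number 13.9 percentage points lower from compound 3 to compound 4 (beyond the scatter), and the same holds against the other two groups, with a number 15.9 percentage points lower from compound 2 to compound 4 (beyond the scatter) and a number 10.1 percentage points lower from compound 1 to compound 4 (beyond the scatter). Methyl, 4-chlorophenyl and 2,4-dimethylphenyl had stayed within the scatter of one another, whereas this change, from one six-membered aromatic ring of carbon only to 2 such rings, is the first here to pass beyond it. Nothing available accounts for the lower number.

The compounds shown leave open whether the lower number goes with the second ring itself or with the way it is attached to the nitrogen. Naphthalen-1-yl or an unsubstituted phenyl on that nitrogen would bear on this question.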